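This account rests on a few compounds, and the source may have more. Where it says the series, first, only, none or still open, it means among the compounds named here.

Measured so far:
compound 1, `CCC(=O)Nc1ccc(-c2nc3cc(C(F)(F)F)ccc3n2C2CCCCC2)cc1`: > 100000 nM
compound 2, `Cn1c(-c2ccc(N)cc2)nc2cc(C(F)(F)F)ccc21`: > 100000 nM
compound 3, `CC(=O)Nc1ccc(-c2nc3cc(C(F)(F)F)ccc3n2C2CCCCC2)cc1`: 30000 nM

For the measured compounds named here, in an ADME assay on Vero cells (Chlorocebus sabaeus) for cytotoxicity (on this read-out lower numbers stand for higher toxicity in this test and higher numbers for lower toxicity in this test), compound 3 gives 30000 nM, the only plain number among the three. The other two values are limits of the assay, as the limit of > 100000 nM in this assay, at which 2 of the 3 values shown sit, records. The value of compound 1 is such a limit. The value of compound 2 is such a limit as well. The one measured step, an at least 3.3-fold lower number from compound 1 to compound 3 (0.52 log units; beyond the scatter), runs along the same amide chain and left compound 3 with the lowest number shown.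

Compound 4, `Nc1ccc(-c2nc3cc(C(F)(F)F)ccc3n2C2CCCCC2)cc1`, differs from compound 3 in one place: hydrogen in place of acetyl on a nitrogen on an aromatic ring. Going by the values given here, no measured step covers this change. Among the compounds with values here, compound 2 does carry the amino group, but it also bears a different group on the other ring nitrogen, so its value shows only that an amino compound of this core can sit at the limit. In this assay a step of modest size toward higher numbers from compound 3 to compound 4 is expected, roughly a 1.7-fold higher number from compound 3 to compound 4 (0.22 log units; within the scatter). Compound 4 is therefore estimated at 50000 nM, with a range from 15000 nM to 150000 nM.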

Compound 4, half-maximal cytotoxic concentration: > 100000 nM
Compound 4: no number, only a limit; the forecaster's own chance of this, stated with the estimate: 45%; at least 2.0-fold (0.30 log units) between middle value and limit.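

In this assay, for the compounds shown here, the change from acetamido to amino on the aromatic ring gives an at least 3.3-fold higher number from compound 3 to compound 4 (0.52 log units; beyond the scatter), the first measured step that removes the whole acyl group from this nitrogen. With this step, compound 3 has a lower number than the compounds carrying propanoyl or hydrogen at this nitrogen, and an at least 3.3-fold lower number from compound 1 to compound 3 (0.52 log units; beyond the scatter) supplies the other side of that comparison. The values of compound 1 and compound 4 are both limits, so the steps from compound 1 and from compound 2 to compound 4 cannot be read, and all three compounds other than compound 3 share one limit: the limit of > 100000 nM in this assay, at which 3 of the 4 values shown sit.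

The compounds shown leave open whether a formyl group or a longer acyl chain such as butanoyl on this nitrogen would give a plain number in this assay. They also leave open whether acetyl on the amino group of compound 2, with methyl kept on the aromatic nitrogen, would do so.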